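Dimethylaminomethyl Cyclohexanones: Swapping the Aryl Halide Pattern

The source may hold more compounds than are shown below. What is called first, only, known or untested is meant among the compounds shown, and "the series" means these compounds.

The study measures four related esters in a functional assay on CCRF-CEM cells (Homo sapiens); a higher number here means a weaker inhibitor, a lower number a stronger inhibitor. Compound 1 `O=C(/C=C/c1ccc(Br)cc1)Oc1ccc(/C=C2\CCCCC2=O)cc1` gives 131000 nM. Compound 2 `O=C(/C=C/c1ccc(Cl)c(Cl)c1)Oc1ccc(/C=C2\CCCCC2=O)cc1` differs by 3,4-dichlorophenyl in place of 4-bromophenyl on a double-bonded chain carbon bound to a double-bonded chain carbon and gives 63800 nM, a step of a 2.1-fold lower number from compound 1 to compound 2 (0.31 log units; beyond the scatter). Compound 3 `CN(C)CC1CCC/C(=C\c2ccc(OC(=O)/C=C/c3ccc(Br)cc3)cc2)C1=O` carries the core change (dimethylamino)methyl in place of hydrogen on a saturated ring carbon and gives 4440 nM, a step of a 30-fold lower number from compound 1 to compound 3 (1.47 log units; beyond the scatter), the lowest number of the three. Compound 4 `CN(C)CC1CCC/C(=C\c2ccc(OC(=O)/C=C/c3ccc(Cl)c(Cl)c3)cc2)C1=O` is not yet measured; it differs from compound 3 by 3,4-dichlorophenyl in place of 4-bromophenyl on a double-bonded chain carbon bound to a double-bonded chain carbon, the same change seen from compound 1 to compound 2, at the same place. Because that earlier step was a 2.1-fold lower number from compound 1 to compound 2 (0.31 log units; beyond the scatter), a similar modest lowering is expected here, giving an estimated step of a 1.9-fold lower number from compound 3 to compound 4 (0.29 log units; within the scatter). Compound 4 is therefore expected to come out near 2300 nM, roughly between 900 nM and 6000 nM.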

Compound 4, half-maximal inhibitory concentration: 5820 nM
Compound 4: the middle estimate sits 2.5-fold (0.40 log units) below what was measured; the range from low to high includes it.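

In this assay, the exchange of 4-bromophenyl for 3,4-dichlorophenyl gave a 1.3-fold higher number from compound 3 to compound 4 (0.12 log units; within the scatter), so the step seen on the core of compound 1 did not carry over in size to the core with (dimethylamino)methyl: the same change on two cores in this assay, a 2.1-fold lower number (0.31 log units; beyond the scatter) from compound 1 to compound 2 and a 1.3-fold higher number (0.12 log units; within the scatter) from compound 3 to compound 4, 2.7-fold (0.43 log units) apart, beyond the scatter of two such steps. The (dimethylamino)methyl change lowered the number on both aryl groups, with an 11-fold lower number from compound 2 to compound 4 (1.04 log units; beyond the scatter), but its size also depended on the partner group: the same change on two cores in this assay, a 30-fold lower number (1.47 log units; beyond the scatter) from compound 1 to compound 3 and an 11-fold lower number (1.04 log units; beyond the scatter) from compound 2 to compound 4, 2.7-fold (0.43 log units) apart, beyond the scatter of two such steps. These two pairs show that the two changes do not add independently here, but they do not show why, nor whether this holds for other cores.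

Going by these compounds, whether a piperidine or a morpholine in place of the dimethylamino group would give a similar step remains open. So does the effect of a longer chain to the amine.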